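A few compounds are considered here, and "the series" means these few. Any claim that something is new, unique, unknown or untested is made for them only; others in the source may bear on it.

Compound 1 `O=S(=O)(NCCCNCc1ccccc1Cl)c1cc(C(F)(F)F)cc(C(F)(F)F)c1` was tested in a functional assay on MIA PaCa-2 cells (Homo sapiens) for inhibition, read by MTT assay, with a stated time of 72 h (on this read-out lower numbers stand for stronger inhibition of growth and higher numbers for weaker inhibition of growth), where compound 1 gives 11000 nM. Among the three measured compounds this is the highest number, though neither gap is meaningful: compound 2 `O=[N+]([O-])c1ccc(S(=O)(=O)NCCCCCCNCc2ccc(Br)cc2)cc1` gives 9800 nM and compound 3 `O=S(=O)(NCCCCCCNCc1ccc(Br)cc1)c1c(Cl)cc(C(F)(F)F)cc1Cl` gives 5670 nM, and both sit within the usual scatter of compound 1. All three share a sulfonamide linked through a saturated chain to a benzylic amine, and the numbers cluster in the same region of weak growth inhibition.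

Compound 4 `COc1cccc(CNCCCNS(=O)(=O)c2cc(C(F)(F)F)cc(C(F)(F)F)c2)c1` differs from compound 1 in one place: 3-methoxyphenyl in place of 2-chlorophenyl on a saturated chain carbon bound to an amine nitrogen. Within the data shown here, no measured pair in this set isolates that change, so there is no step to lean on, and the three measured values give no sign that this part of the molecule moves the number far. The expectation is therefore a step of a 1.1-fold lower number from compound 1 to compound 4 (0.04 log units; within the scatter), which is a change not beyond the scatter. Compound 4 is estimated to give 10000 nM in this assay, with a range from 4000 nM to 25000 nM.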

Compound 4, concentration for 50% growth inhibition: 3400 nM
Estimate against measurement, compound 4: 2.9-fold (0.47 log units) above, outside the stated range (below it).
By their numbers in this assay, from the lowest: compounds 4, 3, 2 and 1 (each within the scatter of the next, the first and the last beyond it).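

In this assay, 3-methoxyphenyl in place of 2-chlorophenyl on a saturated chain carbon bound to an amine nitrogen gives a 3.2-fold lower number from compound 1 to compound 4 (0.51 log units; beyond the scatter). Among these compounds, this modest step shows that the group at this place can move the number beyond the scatter, which the earlier compounds, none differing from another in one place, could not show. Among the compounds shown here, the single exchange does not tell whether the loss of chlorine, the entry of the methoxy group or the different location on the ring carries the step, and nothing measured here gives a reason for it.

The compounds shown leave open how a plain phenyl, a 3-chlorophenyl or a 2-methoxyphenyl would read at this place. They also leave open whether the same exchange would give a similar step on a longer chain.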